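The source may report more compounds than this note shows. Statements on the series, on what has been measured and on what is new or still open speak of the compounds shown alone.

Measured compounds:
- compound 1 `COc1cc(C(O)(C(F)(F)F)C(F)(F)F)cnc1N1CCN(S(=O)(=O)c2ccc(N)nc2)CC1`: < 14 mL.min-1.g-1 (a limit of the assay)
- compound 2 `CS(=O)(=O)Nc1cccc(-c2cc(C(O)(C(F)(F)F)C(F)(F)F)cnc2N2CCN(S(=O)(=O)c3ccc(N)nc3)CC2)c1`: 81 mL.min-1.g-1
- compound 3 `Nc1ccc(S(=O)(=O)N2CCN(c3ncc(C(O)(C(F)(F)F)C(F)(F)F)cc3-c3ccc4ocnc4c3)CC2)cn1`: 120 mL.min-1.g-1

All three compounds were tested in an ADME assay (liver) for metabolic stability, with Liver microsome (Rattus norvegicus) as the target, using microsomes and NADPH, with a stated time of 30 min, tested at 1 uM; a higher number here means faster removal of the compound, a lower number slower removal. They share a core and differ in the group on one aromatic carbon. Compound 1 carries methoxy there, and its entry of < 14 mL.min-1.g-1 is a limit and not a number. Compound 3 gives 120 mL.min-1.g-1, and it stands level with compound 2 within the scatter, as a 1.5-fold higher number from compound 2 to compound 3 (0.17 log units; within the scatter) shows.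

Compound 4 `Nc1ccc(S(=O)(=O)N2CCN(c3ncc(C(O)(C(F)(F)F)C(F)(F)F)cc3-c3cc4ccccc4[nH]3)CC2)cn1` has not yet been measured. It has 1H-indol-2-yl in place of 1,3-benzoxazol-5-yl on an aromatic carbon, (1H-indol-2-yl in place of 1,3-benzoxazol-5-yl on an aromatic carbon).

Two measured steps replace methoxy with a larger aromatic group: an at least 5.7-fold higher number from compound 1 to compound 2 (0.76 log units; beyond the scatter) and an at least 8.5-fold higher number from compound 1 to compound 3 (0.93 log units; beyond the scatter). Neither matches the new change, since compound 3 no longer carries methoxy. Among the measured compounds shown here, the nearest precedent is the exchange of one such aromatic group for another, a 1.5-fold higher number from compound 2 to compound 3 (0.17 log units; within the scatter). On that single precedent, no change beyond the scatter is expected in this assay, and the expected step is a 1.1-fold higher number from compound 3 to compound 4 (0.03 log units; within the scatter). For compound 4 the estimated value is 130 mL.min-1.g-1, with an expected range of 60 mL.min-1.g-1 to 260 mL.min-1.g-1.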

Compound 4, intrinsic clearance in microsomes: 146 mL.min-1.g-1
The estimate for compound 4 lay 1.1-fold (0.05 log units) below the measured number; the range from low to high includes it.
By their numbers in this assay, from the lowest: compounds 2, 3 and 4 (each within the scatter of the next). At a limit, below all of these: compound 1.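

In this assay, the aromatic carbon ortho to a large group takes a third large aromatic group without a change beyond the scatter: replacing 1,3-benzoxazol-5-yl with 1H-indol-2-yl gives a 1.2-fold higher number from compound 3 to compound 4 (0.09 log units; within the scatter), and replacing 3-(methanesulfonamido)phenyl gives a 1.8-fold higher number from compound 2 to compound 4 (0.26 log units; within the scatter), even though these groups differ in their ring hetero atoms and in their counts of hydrogen-bond donors and acceptors. Among compounds 2, 3 and 4, the choice of large aromatic group therefore makes no readable difference to intrinsic clearance in microsomes, whereas the exchange of methoxy for 1H-indol-2-yl gives an at least 10-fold higher number from compound 1 to compound 4 (1.01 log units; beyond the scatter), the only new step beyond the scatter. The entry for compound 1 is a limit and not a number, so the true size of that step stays unknown: the limit of < 14 mL.min-1.g-1 in this assay, at which 1 of the 4 values shown sits.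

The compounds shown do not tell whether the separation from methoxy follows the size of the group or its aromatic rings, as the large groups here are all aromatic and a saturated ring such as morpholine is absent from the set. Nor do they show where a small group such as an amine, a nitrile or a carboxylic acid would fall at this position.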